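The source may report more compounds than this note shows. Statements on the series, on what has been measured and on what is new or still open speak of the compounds shown alone.

Measured compounds:
- compound 1 `CC(C)(C)c1cc(NC(=O)Nc2cc(C(F)(F)F)cc(C(F)(F)F)c2)n(C(C)(C)C)n1`, an assay on isolated protein for inhibition of serine/threonine-protein kinase 10 (Homo sapiens), read by thermal shift assay, tested at 10 uM; on this read-out lower numbers stand for weaker stabilisation of the target and higher numbers for stronger stabilisation of the target against heat: -0.7 degrees C
- compound 2 `Cn1nc(C(C)(C)C)cc1NC(=O)Nc1cc(F)cc(F)c1`, this assay: 1.1 degrees C

Compound 2 stands highest of the two numbers measured in this assay; its nearest neighbour is compound 1, which lies lower by a margin beyond the usual scatter. Going by the values given here, no single-change pair has been measured, so the two values can only be compared as they stand.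

Compound 3 `CC(C)(C)c1cc(NC(=O)Nc2cc(F)cc(F)c2)n(-c2ccc(Br)cc2)n1` is the next step from compound 2. The change is 4-bromophenyl in place of methyl on an aromatic nitrogen. Among the compounds with values here, no measured pair shows what such an exchange does in this assay, so the expectation for compound 3 rests only on compound 2 and its value of 1.1 degrees C. The step is expected to be small, in either direction, and most likely not beyond the scatter, so compound 3 is expected at 1 degrees C, within -1 degrees C to 3 degrees C, which amounts to an expected step of a number 0.10 degrees C lower from compound 2 to compound 3 (within the scatter).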

Compound 3, shift of the target's melting temperature: 0.2 degrees C
Estimate against measurement, compound 3: 0.80 degrees C above, and the stated range covers the measured number.
By their numbers in this assay, from the lowest: compounds 1, 3 and 2 (each within the scatter of the next, the first and the last beyond it).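

Going by these compounds alone, compound 3 gives the first single-change pair in this assay: on the aromatic nitrogen of the five-membered ring, 4-bromophenyl replaces methyl, and the number moves (a number 0.90 degrees C lower from compound 2 to compound 3 (within the scatter)). Going from a group of 1 heavy atom to one of 7 heavy atoms, with a six-membered aromatic ring, therefore leaves the thermal shift within the scatter in this one pair, so this position takes a far larger group without a change that can be told from noise. Nothing at hand explains the size of this step.

The compounds shown leave open what a plain phenyl, a benzyl or a cyclohexyl on the same nitrogen would give, and so whether the bromine or the ring matters at all. They also leave open whether an amine or a carboxylic acid on that phenyl ring would move the number beyond the scatter.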